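Working notes: two measured analogues and one awaiting assay

The compounds below may be only part of what the source reports. "The series", "measured", "known", "first", "only" and "open" are said of these compounds alone.

Measured so far in a functional assay on NCI-H1975 cells (Homo sapiens) for inhibition, read by MTT assay, with a stated time of 72 h; on this read-out higher numbers stand for weaker inhibition and lower numbers for stronger inhibition:
compound 1 `COc1cccc(NC(=O)CSc2nc(Nc3ccccc3)c3ccccc3n2)c1` gives 19400 nM
compound 2 `C=CC(=O)Nc1cccc(NC(=O)CSc2nc(Nc3ccccc3F)c3ccccc3n2)c1` gives 6580 nM

Compound 2 holds the lowest number of the two. Compound 1 sits at a number that is higher by a gap beyond the usual scatter, but the two structures differ in more than one place, so no single step can be read between them; only the two values themselves can be compared.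

Compound 3 `C=CC(=O)Nc1cccc(NC(=O)CSc2nc(Nc3cccc(OC)c3)c3ccccc3n2)c1` is not yet measured in this assay. It differs from compound 2 in one place: 3-methoxyphenyl in place of 2-fluorophenyl on a nitrogen on an aromatic ring

Compound 1 also carries the 3-methoxyphenyl on that nitrogen, yet its other difference from compound 2 leaves the contribution of this one change unresolved. Among the measured compounds shown here, with no single-change step in hand, the size of the change is uncertain. The expectation for the step of a 1.4-fold higher number from compound 2 to compound 3 (0.14 log units; within the scatter) is a small move towards weaker inhibition, not clearly beyond the scatter. Compound 3 is therefore estimated at 9000 nM, within a range from 3000 nM to 30000 nM.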

Compound 3, half-maximal inhibitory concentration: 7940 nM
Beside the measured number, compound 3's estimate is 1.1-fold (0.05 log units) above it; low and high end bracket the measured number.
By their numbers in this assay, from the lowest: compounds 2 and 3 (each within the scatter of the next); then compound 1.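

In this assay, among the compounds shown here, 3-methoxyphenyl in place of 2-fluorophenyl on a nitrogen on an aromatic ring gives a 1.2-fold higher number from compound 2 to compound 3 (0.08 log units; within the scatter), the first single-change reading at this position. For the compounds shown here, the two groups therefore cannot be told apart on this read-out, so this position accepts either the 2-fluorophenyl or the 3-methoxyphenyl without a change that can be separated from the scatter, whereas compound 1 differs from compound 2 and compound 3 in more than one place, and no step to it can be read. No measured evidence accompanies this comparison, and no explanation can be attached to the result.

Going by these compounds alone, only two groups have been compared at this nitrogen in the presence of the shared acrylamide-bearing part, so this reading cannot be extended to the position as a whole. As far as these compounds go, how the read-out would respond to a group of another kind there, such as a phenyl carrying an amine or a carboxylic acid, or a longer alkyl chain in place of the aryl ring, remains open.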